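The compounds below may be only part of what the source reports. "The series", "measured", "known", "first", "only" and "open" are said of these compounds alone.

Compound 1 `CCCCCNc1nc(N)c2nc(O)n(Cc3ccccc3)c2n1` gives 0.3 mg/kg in a functional assay on the whole organism for activation, with Mus musculus as the target; on this read-out lower numbers stand for an effect already at smaller amounts and higher numbers for an effect only at larger amounts of compound. Compound 2 `CSc1nc(N)c2nc(O)n(Cc3ccccc3)c2n1` gives 0.1 mg/kg. Compound 3 `CCCNc1nc(N)c2nc(O)n(Cc3ccccc3)c2n1` gives 1 mg/kg.

Among these three, compound 3 carries the highest number: the step of a 3.3-fold higher number from compound 1 to compound 3 (0.52 log units; beyond the scatter) and the step of a 10-fold higher number from compound 2 to compound 3 (1.00 log units; beyond the scatter) both lead to it, and both lie beyond the scatter, so compound 3 needs the largest amount of the three to show an effect.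

Compound 4 `CCCCc1nc(N)c2nc(O)n(Cc3ccccc3)c2n1` differs from compound 3 in a single place: butyl in place of propylamino on an aromatic carbon. Going by the values given here, two measured steps bear on this change. The first, a 3.3-fold higher number from compound 1 to compound 3 (0.52 log units; beyond the scatter), shows that putting hydrogen in place of ethyl on the chain raised the number; going from propylamino to butyl adds a carbon to the chain again, which points the other way. The second, a 10-fold higher number from compound 2 to compound 3 (1.00 log units; beyond the scatter), shows that the compound with propylamino on that aromatic carbon needed more than the compound with methylsulfanyl there, so replacing propylamino is a move toward the better end of what has been seen. Both considerations point to a lower number for compound 4, of modest size. The step expected is a 3.3-fold lower number from compound 3 to compound 4 (0.52 log units; beyond the scatter). Compound 4 is therefore estimated at 0.3 mg/kg, with a likely range from 0.1 mg/kg to 1 mg/kg.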

Compound 4, minimum effective dose: 0.3 mg/kg
Estimate against measurement, compound 4: no gap at the digits printed, within the range that was stated.
By their numbers in this assay, from the lowest: compound 2; then compounds 1 and 4 (each within the scatter of the next); then compound 3.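

Swapping propylamino for butyl keeps the same count of heavy atoms, yet the number still moves in this assay (a 3.3-fold lower number from compound 3 to compound 4 (0.52 log units; beyond the scatter)), so group size alone does not set the number at this position; the counted difference is that butyl has no hydrogen-bond donor or acceptor, while propylamino has one of each. A nitrogen joining the chain to the aromatic carbon is also not required for an effect at these doses, and butyl cannot be told apart from the longer pentylamino (no change at the digits printed from compound 1 to compound 4 (within the scatter)). Methylsulfanyl keeps its lead over butyl (a 3.0-fold higher number from compound 2 to compound 4 (0.48 log units; beyond the scatter)), so among these groups the shortest chain, the one joined through sulfur, still gives the lowest number.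

No measurement shown here explains why these groups differ. Butylsulfanyl would help separate the role of the sulfur from that of chain length, while butoxy, with oxygen as the joining atom, and a phenyl ring on this aromatic carbon remain open questions.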